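The source may report more compounds than this note shows. Statements on the series, on what has been measured and on what is new or still open speak of the compounds shown alone.

Of the compounds shown here, two have been measured. Compound 1 `C[C@@H]1CN(c2sc(CN(C)C)nc2-c2nc3ccccc3[nH]2)CCN1C(=O)Cn1cnc2cccnc21` gives 1150 nM in an assay on blood for inhibition of C-X-C chemokine receptor type 3 (Homo sapiens), with a stated time of 30 min; a higher number here means a weaker inhibitor, a lower number a stronger inhibitor. Compound 2 `COc1ccc(-c2nc(C(F)(F)F)sc2N2CCN(C(=O)Cn3cnc4cccnc43)[C@H](C)C2)cc1` gives 1190 nM in this assay, the higher of the two numbers, though the gap to compound 1 lies within the scatter, so no order between them is claimed. The next compound, compound 3 `Cc1ncc(-c2nc(C(F)(F)F)sc2N2CCN(C(=O)Cn3cnc4cccnc43)[C@H](C)C2)cn1`, carries 2-methylpyrimidin-5-yl in place of 4-methoxyphenyl on an aromatic carbon. Going by the values given here, no step between measured compounds has been recorded, so nothing about the effect of exchanging the aromatic group on the shared core can be read from the numbers in hand. Without such a precedent the expectation is a step of modest size in this assay, leaning slightly toward a higher number, a 1.3-fold higher number from compound 2 to compound 3 (0.13 log units; within the scatter). Compound 3 is estimated at 1600 nM in this assay, with a range from 600 nM to 4500 nM.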

Compound 3, half-maximal inhibitory concentration: 104 nM
Beside the measured number, compound 3's estimate is 15-fold (1.19 log units) above it, outside the stated range (below it).
By their numbers in this assay, from the lowest: compound 3; then compounds 1 and 2 (each within the scatter of the next).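

In this assay, the aromatic carbon next to the ring nitrogen of the five-membered aromatic ring proves to be a position where the choice of six-membered aromatic group matters strongly: 2-methylpyrimidin-5-yl in place of 4-methoxyphenyl gives an 11-fold lower number from compound 2 to compound 3 (1.06 log units; beyond the scatter). The exchange swaps a ring of carbon only for one with hetero atoms and also changes the substituent on that ring, so this single pair cannot separate the contributions of these differences. No measurement at hand accounts for the step.

From the compounds shown here alone, it remains open whether the gain would hold with a pyridine ring or a pyrimidine ring without the methyl group, or with an amine in place of that methyl group. Compound 1 differs from compound 3 in more than one place, so it gives no reading of this position.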